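Methoxy for Chloro: What Compound 4 Should Give

A few compounds are considered here, and "the series" means these few. Any claim that something is new, unique, unknown or untested is made for them only; others in the source may bear on it.

Measured compounds:
compound 1, `Cc1ccc2cc(-c3ccc(Cl)nn3)c(=O)oc2c1`, in an assay on cells for inhibition of Amine oxidase [flavin-containing] B (Homo sapiens), read by fluorescence and Amplex Red, with a stated time of 15 min (on this read-out lower numbers stand for stronger inhibition and higher numbers for weaker inhibition), compound 1 gives 2510 nM
compound 2, `Cc1cccc2cc(-c3ccc(Cl)nn3)c(=O)oc12`, in this assay compound 2 gives 22700 nM
compound 3, `COc1ccc(-c2cc3ccc(C)cc3oc2=O)nn1`, in this assay compound 3 gives 13500 nM

Compound 1 and compound 2 are built from the same atoms joined differently; the difference between the two cores is not broken down here. Compound 2 gives a higher number than compound 1, beyond the scatter, while compound 2 and compound 3 lie within the scatter of each other.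

Compound 3 arises from compound 1 by one change, (methoxy in place of chloro on an aromatic carbon), and the step is a 5.4-fold higher number from compound 1 to compound 3 (0.73 log units; beyond the scatter).

Compound 4, `COc1ccc(-c2cc3cccc(C)c3oc2=O)nn1`, is not yet measured. It arises from compound 2 by methoxy in place of chloro on an aromatic carbon, the same change made at the same kind of place, described in the same words in both cases.

For the measured compounds named here, the expectation for compound 4 rests on the only precedent: the step from compound 1 to compound 3 is a 5.4-fold higher number from compound 1 to compound 3 (0.73 log units; beyond the scatter), so compound 4 is expected to give a step of a 4.4-fold higher number from compound 2 to compound 4 (0.64 log units; beyond the scatter) from compound 2 in this assay.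

Compound 4 is therefore estimated at 100000 nM, with a range expected from 35000 nM to 300000 nM.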

Compound 4, half-maximal inhibitory concentration: 5350 nM
Estimate against measurement, compound 4: 19-fold (1.27 log units) above; measured number below the stated range.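

On the core of compound 2, methoxy in place of chloro on an aromatic carbon gives a 4.2-fold lower number from compound 2 to compound 4 (0.63 log units; beyond the scatter) in this assay. Set beside the step on the core of compound 1, the same change runs in the opposite direction, and the gap between the two steps is larger than scatter would account for: the same change on two cores in this assay, a 5.4-fold higher number (0.73 log units; beyond the scatter) from compound 1 to compound 3 and a 4.2-fold lower number (0.63 log units; beyond the scatter) from compound 2 to compound 4, 23-fold (1.36 log units) apart, beyond the scatter of two such steps

This shows that, among these compounds, the direction of the change depends on the core that carries it, so a step read on one core cannot simply be carried over to the other; with only one pair on each core, however, it does not show why the steps part, nor how the change would behave on any further core.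

As far as these compounds go, it remains open whether an amine or an ethoxy group in the same place would follow the step to compound 3 or the step to compound 4. From the compounds shown here alone, it also remains open whether either of these groups would separate the two cores as methoxy does.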